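Cyclopentyl for pentyl on the shared core of compound 2

The compounds below may be only part of what the source reports. "The series", "measured", "known", "first", "only" and "open" are said of these compounds alone.

Compound 2 `CCCCCn1c(-c2ccco2)nc2c(NCCCOC)ccnc21` gives the lowest number of the two compounds measured in an assay on isolated protein for inhibition of high affinity 3',5'-cyclic-AMP phosphodiesterase 7A (Homo sapiens), read by cAMP accumulation, with a stated time of 20 min; a higher number here means a weaker inhibitor, a lower number a stronger inhibitor. Compound 1 `COCCNc1ccnc2c1nc(-c1ccco1)n2C1CCCC1` gives 119000 nM in this assay, while compound 2 gives 34200 nM, a gap stated as beyond the scatter. Compound 3 `COCCCNc1ccnc2c1nc(-c1ccco1)n2C1CCCC1` has not been measured; it differs from compound 2 by cyclopentyl in place of pentyl on an aromatic nitrogen. Among the compounds with values here, no direct step of this kind has been measured, and compound 1, which also carries the cyclopentyl group, differs from compound 2 in a second place as well, so its weaker value cannot be attributed to the ring alone. A modest move toward a higher number, at the edge of the scatter, is expected for compound 3, giving a 1.8-fold higher number from compound 2 to compound 3 (0.24 log units; within the scatter). Compound 3 is therefore estimated at 60000 nM in this assay, with a range from 20000 nM to 180000 nM.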

Compound 3, half-maximal inhibitory concentration: 90500 nM
Estimate against measurement, compound 3: 1.5-fold (0.18 log units) below, and the stated range covers the measured number.
By their numbers in this assay, from the lowest: compound 2; then compounds 3 and 1 (each within the scatter of the next).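

In this assay, the change on the aromatic nitrogen can now be read directly: cyclopentyl in place of pentyl gives a 2.6-fold higher number from compound 2 to compound 3 (0.42 log units; beyond the scatter) with the heavy-atom count unchanged, so at this position the ring and the open chain are distinguished, and pentyl carries the lower number. Compound 3 also connects to compound 1 on the side chain, where methoxymethyl in place of methoxy gives a 1.3-fold lower number from compound 1 to compound 3 (0.12 log units; within the scatter) and so separates nothing in this small set. Nothing available accounts for the gap between pentyl and cyclopentyl.

On these data alone, what remains open is how a longer chain such as hexyl, or a larger ring such as cyclohexyl, would read on that nitrogen. As far as these compounds go, it is also open whether an amine in place of the methoxy end of the side chain would move the number at all.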